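Methoxy to Trifluoromethyl in Two Pairs of Analogues

The compounds below may be only part of what the source reports. "The series", "measured", "known", "first", "only" and "open" are said of these compounds alone.

Measured in a functional assay on MCF7 cells (Homo sapiens) for antiproliferative activity, with a stated time of 5 days; on this read-out higher numbers stand for weaker inhibition and lower numbers for stronger inhibition:
compound 1 `CCCCc1ccc2[nH]c(-c3ccc(OC)cc3)c(C=O)c2c1` gives 22 nM
compound 2 `CCCCc1ccc2[nH]c(-c3ccc(C(F)(F)F)cc3)c(C=O)c2c1` gives 66 nM
compound 3 `CCCCc1ccc2[nH]c(-c3ccc(OC)cc3)c(/C=N/NC(=O)c3ccc([N+](=O)[O-])cc3)c2c1` gives 312 nM

Compound 3 stands highest of the three in this assay; the difference between its core and the core of compound 1 is not broken down here. Compound 4 `CCCCc1ccc2[nH]c(-c3ccc(C(F)(F)F)cc3)c(/C=N/NC(=O)c3ccc([N+](=O)[O-])cc3)c2c1` is not yet measured. It differs from compound 3 by trifluoromethyl in place of methoxy on an aromatic carbon. The same change, (trifluoromethyl in place of methoxy on an aromatic carbon), gave a 3.0-fold higher number from compound 1 to compound 2 (0.48 log units; beyond the scatter). As the place is the same word for word in both pairs, the step for compound 4 is expected to be of like size, a 2.9-fold higher number from compound 3 to compound 4 (0.46 log units; beyond the scatter), resting on the shift from compound 1 to compound 2, a 3.0-fold higher number from compound 1 to compound 2 (0.48 log units; beyond the scatter). Compound 4 is therefore estimated at 900 nM in this assay, with an expected range from 400 nM to 2000 nM.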

Compound 4, half-maximal inhibitory concentration: 6340 nM
The estimate for compound 4 lay 7.0-fold (0.85 log units) below the measured number; measured number above the stated range.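

In this assay, trifluoromethyl in place of methoxy gave a 20-fold higher number from compound 3 to compound 4 (1.31 log units; beyond the scatter), so the number rose on both cores, but the size of the step did not carry over: the same change on two cores in this assay, a 3.0-fold higher number (0.48 log units; beyond the scatter) from compound 1 to compound 2 and a 20-fold higher number (1.31 log units; beyond the scatter) from compound 3 to compound 4, 6.8-fold (0.83 log units) apart, beyond the scatter of two such steps

A step read on the core of compound 1 therefore gives the direction on the core of compound 3, not a reliable size. These two pairs do not show which part of the cores sets the size of the step, or how the change would behave on a third core.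

From the compounds shown here alone, it remains open whether a nitrile or a chlorine atom in place of methoxy would also give steps that differ between the two cores. Also open, going by these compounds, is whether an amine in place of the nitro group would alter the gap between them.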